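A few compounds are considered here, and "the series" means these few. Any claim that something is new, unique, unknown or untested is made for them only; others in the source may bear on it.

Notes on the series. Compound 1 `CC1(C)CCNc2ccc(NC(=S)Nc3ccc(C(F)(F)F)cc3)cc21` and compound 2 `CC1(C)CCNc2ccc(NC(=S)Nc3ccc(OC(F)(F)F)cc3)cc21` share one core; compound 3 `CN1c2ccc(NC(=S)Nc3ccc(C(F)(F)F)cc3)cc2C(C)(C)C(=O)C1(C)C` and compound 4 `CN1c2ccc(NC(=S)Nc3ccc(OC(F)(F)F)cc3)cc2C(C)(C)C(=O)C1(C)C` share another. The difference between the two cores is not broken down here. In a functional assay on A2780 cells (Homo sapiens) for inhibition, with a stated time of 72 h (a lower number here means a stronger inhibitor, a higher number a weaker inhibitor), compound 1 gives 6000 nM and compound 2 gives 7100 nM; in this assay compound 3 gives 3900 nM. The values of compound 1 and compound 3 lie within the usual scatter of one another, as do those of compound 2 and compound 3, so no order among the three measured compounds can be read from them.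

The change from compound 1 to compound 2 is trifluoromethoxy in place of trifluoromethyl on an aromatic carbon. It made a 1.2-fold higher number from compound 1 to compound 2 (0.07 log units; within the scatter). The same change, (trifluoromethoxy in place of trifluoromethyl on an aromatic carbon), carries compound 3 to compound 4; it occurs twice among the compounds here, once measured and once not. Going by the values given here, the surroundings of the change are the same in both cases, so the two changes count as the same change, but only one measured instance is available, and whether the second core responds in the same way is not known.

Among the compounds with values here, for compound 4 in this assay the expected step is a 1.2-fold higher number from compound 3 to compound 4 (0.06 log units; within the scatter), because a 1.2-fold higher number from compound 1 to compound 2 (0.07 log units; within the scatter) is the only measured instance of this change and nothing else about it is known. Compound 4 is therefore estimated at 4500 nM, with a range from 2500 nM to 9000 nM expected to hold most repeat measurements.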

Compound 4, half-maximal inhibitory concentration: 5400 nM
Beside the measured number, compound 4's estimate is 1.2-fold (0.08 log units) below it, within the range that was stated.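

Placing trifluoromethoxy in place of trifluoromethyl on the core of compound 3 gives a 1.4-fold higher number from compound 3 to compound 4 (0.14 log units; within the scatter) in this assay, and this step does not differ from the one measured on the core of compound 1: the same change on two cores in this assay, a 1.2-fold higher number (0.07 log units; within the scatter) from compound 1 to compound 2 and a 1.4-fold higher number (0.14 log units; within the scatter) from compound 3 to compound 4, 1.2-fold (0.07 log units) apart, within the scatter of two such steps. In these two pairs the change therefore carries from one core to the other, with both steps staying within the scatter and no sign that either core responds to it in its own way. This does not show that the change has any real effect on the read-out, as neither step stands clear of the scatter, and two pairs of compounds cannot establish how the change would behave on a further core.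

The compounds shown leave open whether a different group on the same aromatic carbon, such as a nitrile, a chlorine or an amine, would give a step beyond the scatter, as only trifluoromethyl and trifluoromethoxy appear there. Going by these compounds alone, they also leave open which features of the two cores matter to the read-out, since the cores differ in more than one place and no compound here separates those differences.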